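A Smaller Aryl Group on the Triazole Benzyl Arm

A few compounds are considered here, and "the series" means these few. Any claim that something is new, unique, unknown or untested is made for them only; others in the source may bear on it.

Measured compounds:
- compound 1, `O[C@H](COCCOC[C@@H](O)Cc1cn(Cc2ccc3ccccc3c2)nn1)Cc1ccc(-c2ccccc2)cc1`, giving 12100 nM in a functional assay on SGC-7901 cells (Homo sapiens) for inhibition, read by MTT assay, with a stated time of 72 h; a higher number here means a weaker inhibitor of growth, a lower number a stronger inhibitor of growth
- compound 2, `O=C1COc2ccc(-n3cc(C[C@H](O)COCCOC[C@@H](O)Cc4ccc(-c5ccccc5)cc4)nn3)cc2N1`, giving 15200 nM in this assay
- compound 3, `O[C@H](COCCOC[C@@H](O)Cc1cn(-c2cncc3ccccc23)nn1)Cc1ccc(-c2ccccc2)cc1`, giving 29300 nM in this assay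

Compound 1 stands lowest of the three numbers in this assay, so it is the strongest growth inhibitor of this small group, though only its gap to compound 3 is beyond the scatter. Going from compound 1 to compound 2 gives a 1.3-fold higher number from compound 1 to compound 2 (0.10 log units; within the scatter), and going from compound 1 to compound 3 gives a 2.4-fold higher number from compound 1 to compound 3 (0.38 log units; beyond the scatter).

Compound 4, `N#Cc1ccc(Cn2cc(C[C@H](O)COCCOC[C@@H](O)Cc3ccc(-c4ccccc4)cc3)nn2)cc1`, keeps the shared core and the chain of compound 1 and changes only the aryl group on the benzyl arm: 4-cyanophenyl in place of naphthalen-2-yl on a saturated chain carbon bound to an aromatic nitrogen. Neither measured step bears on this directly, since both of them change the whole substituent on the aromatic nitrogen rather than swapping one aryl group for another on the saturated chain carbon. Among the compounds with values here, all three measured compounds sit within a narrow band, and the one change that left the benzyl link intact in spirit, compound 1 to compound 2, stayed within the scatter. The expectation for compound 4 is therefore a step of about a 1.2-fold higher number from compound 1 to compound 4 (0.09 log units; within the scatter), not beyond the scatter, in this assay. Compound 4 is estimated at 15000 nM, with a likely range from 7000 nM to 35000 nM.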

Compound 4, concentration for 50% growth inhibition: 7700 nM
Estimate against measurement, compound 4: 1.9-fold (0.29 log units) above, within the range that was stated.
By their numbers in this assay, from the lowest: compounds 4, 1, 2 and 3 (each within the scatter of the next, the first and the last beyond it).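

Replacing naphthalen-2-yl with 4-cyanophenyl on a saturated chain carbon bound to an aromatic nitrogen leaves growth inhibition in this assay within the scatter (a 1.6-fold lower number from compound 1 to compound 4 (0.20 log units; within the scatter)), so this place tolerates one aromatic ring carrying a nitrile as well as two aromatic rings without a nitrile. The 4-cyanobenzyl group also stays within the scatter of the group on the aromatic nitrogen in compound 2 (a 2.0-fold lower number from compound 2 to compound 4 (0.30 log units; within the scatter)), but it stands clearly apart from isoquinolin-4-yl (a 3.8-fold lower number from compound 3 to compound 4 (0.58 log units; beyond the scatter)), which gives the widest gap in this set and the first one beyond the scatter that involves compound 4. Nothing shown here accounts for any of these steps.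

The compounds shown do not separate the contribution of the nitrile from that of the single aromatic ring, since plain benzyl, with no group on its ring, is absent from this set. They also leave open whether a different group in the place of the nitrile on the benzyl ring, such as a carboxylic acid, an amine or a methoxy group, would keep compound 4's level of growth inhibition.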